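Swapping tert-Butyl for Chloro in a Weakly Cytotoxic Series

The compounds below may be only part of what the source reports. "The series", "measured", "known", "first", "only" and "open" are said of these compounds alone.

Of the compounds shown here, three have been tested in a functional assay on HL-60 cells (Homo sapiens) for cytotoxicity, read by MTT assay, with a stated time of 24 h; a lower number here means a stronger inhibitor, a higher number a weaker inhibitor. Compound 1 `Clc1ccc(-c2nnc(SCCCN3CCN(c4ncccn4)CC3)[nH]2)cc1` gives 105000 nM. For compound 2 `CC(C)(C)c1ccc(-c2nn(CCCN3CCN(c4ccccc4)CC3)c(=S)[nH]2)cc1` only a limit of the assay was reached, > 300000 nM. Compound 3 `CC(C)(C)c1ccc(-c2nn(CCCN3CCN(c4cccc(Cl)c4)CC3)c(=S)[nH]2)cc1` likewise stands at a limit, > 300000 nM. Going by the values given here, the one measured step within this group, a step that the two limits leave unreadable from compound 2 to compound 3, cannot be sized, since both of its ends sit at the limit of > 300000 nM in this assay, at which 2 of the 3 values shown sit. Compound 4 `S=c1[nH]c(-c2ccc(Cl)cc2)nn1CCCN1CCN(c2cccc(Cl)c2)CC1` differs from compound 3 by chloro in place of tert-butyl on an aromatic carbon. Among the compounds with values here, no measured step matches this change, and the measured values are all far from potent, so no shift beyond the usual scatter can be read out in this assay in either direction. Compound 4 is therefore expected to give about 250000 nM, within 80000 nM to 600000 nM. That expectation corresponds to the step of an at least 1.2-fold lower number from compound 3 to compound 4 (0.07 log units; that floor lies within the scatter).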

Compound 4, half-maximal inhibitory concentration: 6670 nM
Beside the measured number, compound 4's estimate is 37-fold (1.57 log units) above it; the whole stated range lies above it.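

In this assay, the change from 4-(tert-butyl)phenyl to 4-chlorophenyl gives an at least 44-fold lower number from compound 3 to compound 4 (1.65 log units; beyond the scatter), the first readable sign that this position can move the result. Compound 3 stands at a limit, > 300000 nM. The true size of the step therefore stays unknown, with only its lower bound readable: the limit of > 300000 nM in this assay, at which 2 of the 4 values shown sit.

Going by these compounds, what a methoxy group or a plain hydrogen at this position would give remains open. So does whether the same change would act alike on compound 2.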